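Swapping an amine chain for difluoromethyl

The source may report more compounds than this note shows. Statements on the series, on what has been measured and on what is new or still open speak of the compounds shown alone.

In an ADME assay for pharmacokinetics, read by LC-MS, in phosphate buffer, with a stated time of 120 min, at pH 7.4, tested at 1 uM, in the presence of a further agent that is not named here (a lower number here means that the compound disappears faster, a higher number that the compound lasts longer), compound 1 `C=C(C(=O)Nc1ccccc1)C(F)(F)F` gives 0.25 h as its half-life. Compound 3 `CN(C)CC/C=C/C(=O)Nc1ccccc1` gives 7.38 h and so holds the higher of the two exact numbers, with a gap to compound 1 that lies beyond the scatter. For compound 2 `C=C(Cc1ccccc1)C(=O)Nc1ccccc1` the result > 8.53 h is a limit and not a number.

Compound 4 `O=C(/C=C/C(F)F)Nc1ccccc1` has not yet been measured. It carries difluoromethyl in place of 2-(dimethylamino)ethyl on a double-bonded chain carbon bound to a double-bonded chain carbon. Going by the values given here, compound 1 is the one measured compound with fluorine, and its 0.25 h in this assay is the only guide to this change. A single compound is thin support, but compound 4 is expected to last less long than compound 3. The expected change is a 4.9-fold lower number from compound 3 to compound 4 (0.69 log units; beyond the scatter) and would lie beyond the scatter. The estimate for compound 4 is 1.5 h with an expected range of 0.3 h to 6 h in this measurement.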

Compound 4, half-life: 0.733 h
Estimate against measurement, compound 4: 2.0-fold (0.31 log units) above; the measured number falls inside the stated range.
By their numbers in this assay, from the lowest: compound 1; then compound 4; then compound 3. At a limit, above all of these: compound 2.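

Going by these compounds alone, this is the first step in the set where only one place changes: with difluoromethyl in place of 2-(dimethylamino)ethyl on a double-bonded chain carbon bound to a double-bonded chain carbon, this assay shows a 10-fold lower number from compound 3 to compound 4 (1.00 log units; beyond the scatter). Within the data shown here, until now, the only fluorine-bearing guide was compound 1, which differs from compound 3 in more than one place, so this pair is the first direct sign that the group at this position alone can shift the half-life. None of the data shown gives a reason for the shift.

Going by these compounds, what remains open is whether the shorter half-life of compound 4 comes from losing the amine chain or from gaining the fluorine atoms. A plain methyl group at this place would help separate the two, and a longer chain ending in the same dimethylamine would show how much the chain length counts.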